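Swapping a Carboxyphenyl for an Aminofluorophenyl Sulfone

This account rests on a few compounds, and the source may have more. Where it says the series, first, only, none or still open, it means among the compounds named here.

Measured so far:
compound 1, `Cn1c(=O)c(S(=O)(=O)c2ccc(C(=O)O)cc2)cc2cnc(Nc3ccc4[nH]ccc4c3)nc21`: 5000 nM
compound 2, `O=c1c(S(=O)(=O)c2ccc(F)cc2F)cc2cnc(Nc3ccc4[nH]ccc4c3)nc2n1CC1CC1`: 1000 nM

In a functional assay on K562 cells (Homo sapiens) for inhibition, read by trypan blue exclusion, with a stated time of 72 h (a lower number here means a stronger inhibitor, a higher number a weaker inhibitor), compound 1 gives 5000 nM, the highest of the two numbers. Compound 2 gives 1000 nM, a lower number beyond the scatter. Compound 3, `Cn1c(=O)c(S(=O)(=O)c2ccc(N)cc2F)cc2cnc(Nc3ccc4[nH]ccc4c3)nc21`, is not yet measured. It differs from compound 1 in one place: 4-amino-2-fluorophenyl in place of 4-carboxyphenyl on a sulfonyl sulfur. Within the data shown here, no measured pair isolates this change, so the expectation leans on compound 2 giving 1000 nM with a fluorine-bearing ring on the sulfonyl sulfur. Compound 3 is expected to move a 3.3-fold lower number from compound 1 to compound 3 (0.52 log units; beyond the scatter) toward a stronger inhibitor, landing at an estimated 1500 nM, within 500 nM to 5000 nM.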

Compound 3, half-maximal inhibitory concentration: 1500 nM
The estimate for compound 3 equals the measured number at the digits printed, within the range that was stated.
By their numbers in this assay, from the lowest: compounds 2 and 3 (each within the scatter of the next); then compound 1.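

Changing only the ring on the sulfonyl sulfur does alter the result. In this assay the swap to 4-amino-2-fluorophenyl brings a 3.3-fold lower number from compound 1 to compound 3 (0.52 log units; beyond the scatter) with the rest of the molecule unchanged, a modest step. The carboxylic acid is therefore not required for activity in these cells, though nothing measured here explains the step.

As far as these compounds go, the swap removes the carboxylic acid and adds both an amine and a fluorine, so the contribution of each remains open. A plain phenyl ring, or a methyl ester in place of the acid, would help separate them.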